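The source may hold more compounds than are shown below. What is called first, only, known or untested is meant among the compounds shown, and "the series" means these compounds.

Of the compounds shown here, two of a shared core have been tested in a functional assay on the whole organism (strain Jcl:Sprague-Dawley) for inhibition, with Rattus norvegicus as the target, with stated times of 3 min and 3 h, at a dose of 1 mg/kg by the intravenous route; a higher number here means more inhibition at the dose given (going by the name of the read-out), a lower number less inhibition. Compound 1 `CNCc1cc(-c2cccnc2F)n(S(=O)(=O)c2ccccn2)c1` carries an unsubstituted pyridine on the sulfonyl sulfur, and in this assay compound 1 gives 81%. Compound 2 `CNCc1cn(S(=O)(=O)c2ccc(OC)cn2)c(-c2cccnc2F)c1F` differs in more than one place from compound 1, so no single step can be read between them; in this assay compound 2 gives 95%, which is the higher of the two numbers, and its lead over compound 1 is beyond the scatter of repeated measurements.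

Compound 3 `CNCc1cn(S(=O)(=O)c2cncc(F)c2)c(-c2cccnc2F)c1F` has not yet been measured. It keeps the core of compound 2 and changes only the group on the sulfonyl sulfur: 5-fluoropyridin-3-yl in place of 5-methoxypyridin-2-yl on a sulfonyl sulfur. Both groups are six-membered aromatic rings with one nitrogen, so the change is modest in size. Among the compounds with values here, since no single-point step between measured compounds is available, the direction is uncertain; the step in this assay is expected to be small, a number 10 percentage points lower from compound 2 to compound 3 (within the scatter), within or only slightly beyond the scatter. The estimate for compound 3 in this assay is 85%, with a range from 70% to 97%.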

Compound 3, a percentage reported as inhibition, in the whole organism at one dose (the size of the read-out at that dose, not a potency): 99%
For compound 3 the middle estimate is 14 percentage points below the measured one; measured number outside the range, above it.
By their numbers in this assay, from the lowest: compound 1; then compounds 2 and 3 (each within the scatter of the next).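

Within the data shown here, the change from 5-methoxypyridin-2-yl to 5-fluoropyridin-3-yl on a sulfonyl sulfur gives the first step that can be read at a single place, and in this assay it is a number 4 percentage points higher from compound 2 to compound 3 (within the scatter) at this dose. Earlier, the group on the sulfur could only be seen changing together with other parts of the molecule; here it changes alone, and the read-out does not tell the two rings apart, even though one carries a methoxy group and the other a fluorine. No measurement shown here accounts for this step.

With compound 3 at 99% little room remains on this percentage scale, so a single dose may not separate further groups on the sulfonyl sulfur. Also open, on these data alone, is what a phenyl ring, or a pyridine ring carrying an amine or a carboxylic acid, would give at this place, and whether a lower dose would pull compound 2 and compound 3 apart.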